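Removing the methoxy group from a catechol arginase-1 inhibitor

A few compounds are considered here, and "the series" means these few. Any claim that something is new, unique, unknown or untested is made for them only; others in the source may bear on it.

Measured compounds:
- compound 1, `COc1ccc(NCc2ccc(O)c(O)c2)cc1`: 154000 nM
- compound 2, `O=C(O)c1cc(NCc2ccc(O)c(O)c2)ccc1O`: 187000 nM
- compound 3, `N=C(NO)NCC[C@H](N)C(=O)O`: 2700 nM

Of the compounds shown here, three have been measured in an assay on liver for inhibition of arginase-1 (Bos taurus), with a stated time of 60 min; on this read-out lower numbers stand for stronger inhibition and higher numbers for weaker inhibition. Compound 1 gives 154000 nM, the second highest of the three numbers. Compound 2 gives 187000 nM, and the gap between compound 1 and compound 2 lies within the scatter, so no order can be read between them. Compound 3 gives 2700 nM, a much lower number than either, well beyond the scatter.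

The next compound, compound 4, `Oc1ccc(CNc2ccccc2)cc1O`, differs from compound 1 in one place: hydrogen in place of methoxy on an aromatic carbon. For the measured compounds named here, the change is small in size, and no step between measured compounds reports what such a change does on this read-out. With compound 1 standing at 154000 nM, the step is expected to lie within the scatter, in no definite direction, so a 1.1-fold higher number from compound 1 to compound 4 (0.04 log units; within the scatter) is the estimated step. Compound 4 is therefore expected to give about 170000 nM, within a range from 60000 nM to 500000 nM.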

Compound 4, half-maximal inhibitory concentration: 164000 nM
Beside the measured number, compound 4's estimate is 1.0-fold (0.02 log units) above it; low and high end bracket the measured number.
By their numbers in this assay, from the lowest: compound 3; then compounds 1, 4 and 2 (each within the scatter of the next).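

For the compounds shown here, compound 4 gives the first step at this position: hydrogen in place of methoxy, on an aromatic carbon para to a large group, gives a 1.1-fold higher number from compound 1 to compound 4 (0.03 log units; within the scatter) in this assay. On this read-out, therefore, the methoxy group can be exchanged for hydrogen at this place with no change that can be told from the scatter, and the core of compound 1 needs no group there to reach the number it gives. Nothing at hand explains why the step is this small.

Going by these compounds, whether a nitrile, a trifluoromethyl group or a chlorine atom at the same place would move the number beyond the scatter remains open. On these data alone, what the hydroxyl groups of the shared core contribute also stays open.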